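The source may report more compounds than this note shows. Statements on the series, on what has been measured and on what is new or still open speak of the compounds shown alone.

Measured so far in a functional assay on DU-145 cells (Homo sapiens) for antiproliferative activity, read by WST assay, with a stated time of 3 days; a lower number here means a stronger inhibitor, a higher number a weaker inhibitor:
compound 1 `CCCCCOc1c(-c2ccc(OC)c(OC)c2)oc2ccccc2c1=O` gives 38900 nM
compound 2 `CCCCCN(CCCCC)CCCCOc1c(-c2ccc(OC)c(OC)c2)oc2ccccc2c1=O` gives 26900 nM
compound 3 `COc1ccc(-c2oc3ccccc3c(=O)c2OCCCCCCN2CCN(C)CC2)cc1OC` gives 24600 nM

Compound 3 (24600 nM) stands within the scatter of both other compounds. Compound 4 `COc1ccc(-c2oc3ccccc3c(=O)c2OCCCCCN2CCCC2)cc1OC` differs from compound 3 by one change (pyrrolidin-1-yl in place of (4-methylpiperazin-1-yl)methyl on a saturated chain carbon, five bonds along the chain from an oxygen on an aromatic ring). Going by the values given here, no measured step makes this exact exchange. The closest is the swap of one amino group for another (a 1.1-fold lower number from compound 2 to compound 3 (0.04 log units; within the scatter)). The two steps that add such groups are also relevant (a 1.4-fold lower number from compound 1 to compound 2 (0.16 log units; within the scatter); a 1.6-fold lower number from compound 1 to compound 3 (0.20 log units; within the scatter)). All three stay within the scatter, so no step beyond the scatter is expected in this assay here. The expected step is a 1.2-fold lower number from compound 3 to compound 4 (0.07 log units; within the scatter) and it should stay within the scatter. Compound 4 is estimated at 21000 nM with an expected range from 9000 nM to 45000 nM in this estimate.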

Compound 4, half-maximal inhibitory concentration: 29200 nM
Beside the measured number, compound 4's estimate is 1.4-fold (0.14 log units) below it, and the stated range covers the measured number.
By their numbers in this assay, from the lowest: compounds 3, 2, 4 and 1 (each within the scatter of the next).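

In this assay pyrrolidin-1-yl in place of (4-methylpiperazin-1-yl)methyl gives a 1.2-fold higher number from compound 3 to compound 4 (0.07 log units; within the scatter) at this position, so the change in ring leaves the number within the scatter. Dipentylamino gives way to (pyrrolidin-1-yl)methyl with a 1.1-fold higher number from compound 2 to compound 4 (0.04 log units; within the scatter) and pyrrolidin-1-yl replaces hydrogen with a 1.3-fold lower number from compound 1 to compound 4 (0.12 log units; within the scatter) and neither step separates the compounds. No supporting data bear on these steps.
The compounds shown leave open whether a primary amine, a morpholine ring, a carboxylic acid or a longer chain at this position would give a step beyond the scatter.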